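The source may report more compounds than this note shows. Statements on the series, on what has been measured and on what is new or still open speak of the compounds shown alone.

Compound 1 `COc1cc(N(C)CCN(C)C)c(NC(=O)c2ccnc(Cl)c2)cc1Nc1nccc(-c2cn(CCCO)c3ccccc23)n1` gives 1820 nM in a functional assay on NCI-H1975 cells (Homo sapiens) for antiproliferative activity, read by MTT assay, with a stated time of 72 h; on this read-out lower numbers stand for stronger inhibition and higher numbers for weaker inhibition. Compound 2 `COc1cc(N(C)CCN(C)C)c(NC(=O)c2ccncc2OC)cc1Nc1nccc(-c2cn(CCCO)c3ccccc23)n1` gives 1970 nM in this assay, the highest of the two numbers, with compound 1 the nearest, the gap being within the scatter. Compound 3 `COc1cc(N(C)CCN(C)C)c(NC(=O)c2ccncn2)cc1Nc1nccc(-c2cn(CCCO)c3ccccc23)n1` carries pyrimidin-4-yl in place of 3-methoxypyridin-4-yl on a carbonyl carbon. For the measured compounds named here, the one measured step at the same carbonyl carbon, a 1.1-fold higher number from compound 1 to compound 2 (0.03 log units; within the scatter), moved the number hardly at all, so in this assay no step beyond the scatter is expected here either. The estimate for compound 3 in this assay is 2000 nM, range 900 nM to 4500 nM, corresponding to an expected step of a 1.0-fold higher number from compound 2 to compound 3 (0.01 log units; within the scatter).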

Compound 3, half-maximal inhibitory concentration: 2120 nM
Estimate against measurement, compound 3: 1.1-fold (0.03 log units) below; low and high end bracket the measured number.
By their numbers in this assay, from the lowest: compounds 1, 2 and 3 (each within the scatter of the next).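

At this carbonyl carbon, a ring with two hetero atoms now joins the two pyridines in this assay: pyrimidin-4-yl in place of 3-methoxypyridin-4-yl gives a 1.1-fold higher number from compound 2 to compound 3 (0.03 log units; within the scatter), and in place of 2-chloropyridin-4-yl it gives a 1.2-fold higher number from compound 1 to compound 3 (0.07 log units; within the scatter). The loss of the methoxy or chloro group together with the added ring nitrogen therefore separates none of the three compounds. Nothing available explains this flat result.

Open, from the compounds shown here alone, is whether a non-aromatic group here, such as a piperidine ring or a simple aminomethyl, would move the number beyond the scatter.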